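Acetyl for fluoro on the outer ring of compound 3

A few compounds are considered here, and "the series" means these few. Any claim that something is new, unique, unknown or untested is made for them only; others in the source may bear on it.

Measured so far:
compound 1, `CCNC(=O)CCc1cccc2c1B(O)OC2`, > 100000 nM
compound 2, `O=C(CCc1cccc2c1B(O)OC2)Nc1ccc(Cl)cc1`, 5000 nM
compound 3, `O=C(CCc1cccc2c1B(O)OC2)Nc1cccc(-c2cccc(F)c2)c1`, 480 nM

Of the compounds shown here, three sharing one boron-containing core have been tested in a functional assay on SK-OV-3 cells (Homo sapiens) for antiproliferative activity, read by MTT assay, with a stated time of 72 h; a lower number here means a stronger inhibitor, a higher number a weaker inhibitor. For compound 1 the result is only a limit of the assay, (the limit of > 100000 nM in this assay, at which 1 of the 3 values shown sits), not a number. Going by the values given here, compound 2 gives 5000 nM, and the step of an at least 20-fold lower number from compound 1 to compound 2 (1.30 log units; beyond the scatter) is the one measured change. Compound 3 gives 480 nM, the lowest of the two numbers, and its gap to compound 2 lies beyond the scatter.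

The next compound, compound 4, `CC(=O)c1cccc(-c2cccc(NC(=O)CCc3cccc4c3B(O)OC4)c2)c1`, differs from compound 3 by acetyl in place of fluoro on an aromatic carbon. No measured step touches this outer ring, so nothing shown bears directly on the change; the one measured step concerns the amide-type nitrogen instead. With no guide either way, no step beyond the scatter is expected in this assay. Compound 4 is therefore estimated at 500 nM, between 150 nM and 1700 nM, meaning an expected step of a 1.0-fold higher number from compound 3 to compound 4 (0.02 log units; within the scatter).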

Compound 4, half-maximal inhibitory concentration: 68 nM
Estimate against measurement, compound 4: 7.4-fold (0.87 log units) above, outside the stated range (below it).
By their numbers in this assay, from the lowest: compound 4; then compound 3; then compound 2. At a limit, above all of these: compound 1.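

In this assay, the outer ring turns out to be a place where a single change counts: going from 3-fluorophenyl to 3-acetylphenyl gives a 7.1-fold lower number from compound 3 to compound 4 (0.85 log units; beyond the scatter) and leaves the rest of the molecule untouched. Until now the only listed step lay elsewhere, on the amide-type nitrogen, so this is the first measured sign that a group on this aromatic carbon, meta to a large group, can move the number beyond the scatter. Nothing shown here speaks to why acetyl gives a lower number than fluoro.

As far as these compounds go, it stays open whether acetyl is special or whether other groups at this place, such as a nitrile, an amine or a carboxylic acid, would give similar numbers. How acetyl would fare elsewhere on the outer ring is also still unknown.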